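Pyrazolopyrimidinone-piperidinol series: benzyl swap toward compound 4

The source may report more compounds than this note shows. Statements on the series, on what has been measured and on what is new or still open speak of the compounds shown alone.

Working notes on a small set of compounds sharing one core. Compound 1 `O=c1c2cnn(-c3ccc(F)cc3)c2ncn1CC1(O)CCN(Cc2ccccc2)CC1` carries a plain benzyl group on the ring amine and in an assay on Sf21 cells for inhibition of ubiquitin carboxyl-terminal hydrolase 7 (Homo sapiens), read by spectrophotometry, with stated times of 30 min and 2 h (a higher number here means a weaker inhibitor, a lower number a stronger inhibitor), compound 1 gives "not determined" (no result reported). Compound 2 `O=c1c2cnn(-c3ccc(F)cc3)c2ncn1CC1(O)CCN(Cc2ccc(C(F)(F)F)cc2)CC1` carries a 4-(trifluoromethyl)benzyl group and in this assay compound 2 likewise gives "not determined" (no result reported); it therefore stands without a number, alongside compound 1, which also lacks one. Going by the values given here, the only measured member is compound 3 `COC(=O)c1ccc(CN2CCC(O)(Cn3cnc4c(cnn4-c4ccc(F)cc4)c3=O)CC2)c(F)c1`, which in this assay gives 800 nM.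

Compound 4 `COC(=O)c1ccc(CN2CCC(O)(Cn3cnc4c(cnn4-c4ccc(F)cc4)c3=O)CC2)c(Br)c1` is the compound to be measured. Its difference from compound 2 is 2-bromo-4-(methoxycarbonyl)phenyl in place of 4-(trifluoromethyl)phenyl on a saturated chain carbon bound to an amine nitrogen in a ring. Among the compounds with values here, no step between measured compounds is available, so the size of the change from compound 2 to compound 4 in this assay cannot be read from a measured pair; compound 2 has no number from which a direction could be taken. The expectation for compound 4 rests on compound 3, whose value of 800 nM is the only anchor in this assay, and that anchor sits in the sub-micromolar range. On that basis compound 4 is expected to give about 600 nM in this assay, with a plausible range from 200 nM to 2000 nM.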

Compound 4, half-maximal inhibitory concentration: 900 nM
Estimate against measurement, compound 4: 1.5-fold (0.18 log units) below; low and high end bracket the measured number.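

In this assay, going by these compounds alone, the exchange of fluoro for bromo on an aromatic carbon gives a 1.1-fold higher number from compound 3 to compound 4 (0.05 log units; within the scatter) and is the first step between measured compounds. This read-out therefore does not separate the two halogens on the 4-(methoxycarbonyl)benzyl group, and that group now has a number with each of them, which compound 1 and compound 2 do not supply for their own benzyl groups. Nothing shown gives a reason for this outcome.

Going by these compounds, the steps from compound 1 or compound 2 to the measured compounds cannot be read, so what the methoxycarbonyl group contributes to the value remains unknown, as does whether a halogen on the ring is needed at all. Also open, on these data alone, is how a plain hydrogen or a chloro group at the halogen's place would read in this assay, and how a carboxylic acid or a primary amide in place of the methyl ester would read.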